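Swapping a saturated ring for an aromatic one

A few compounds are considered here, and "the series" means these few. Any claim that something is new, unique, unknown or untested is made for them only; others in the source may bear on it.

In an assay on isolated protein for binding affinity to Leucine-rich repeat serine/threonine-protein kinase 2 variant G2019S (Homo sapiens), read by TR-FRET and LanthaScreen, with a stated time of 2 h (a lower number here means a stronger inhibitor, a higher number a weaker inhibitor), compound 1 `C[C@@H]1CCCN1c1c(C#N)c2c(N)nc(Nc3cn[nH]c3)nc2n1C` gives 0.4 nM, and compound 2 `C[C@@H]1CCCN1c1c(C#N)c2c(N)ncnc2n1C` gives 0.7 nM; the step of a 1.8-fold higher number from compound 1 to compound 2 (0.24 log units; within the scatter) lies within the scatter, so compound 2 sits alongside compound 1 rather than apart from it. Compound 3 `Cn1c(-n2cccc2)c(C#N)c2c(N)ncnc21` differs from compound 2 by 1H-pyrrol-1-yl in place of 2-methylpyrrolidin-1-yl on an aromatic carbon. Going by the values given here, no measured step touches this position, so the size and direction of the change in this assay are not anchored by the data. Compound 3 is therefore expected at 3 nM, in the range 0.7 nM to 15 nM, a step of a 4.3-fold higher number from compound 2 to compound 3 (0.63 log units; beyond the scatter) that carries wide uncertainty.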

Compound 3, inhibition constant: 1980 nM
The estimate for compound 3 lay 660-fold (2.82 log units) below the measured number, and the stated range ends below it.
By their numbers in this assay, from the lowest: compounds 1 and 2 (each within the scatter of the next); then compound 3.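

Replacing 2-methylpyrrolidin-1-yl with 1H-pyrrol-1-yl gives a step of a 2800-fold higher number from compound 2 to compound 3 (3.45 log units; beyond the scatter) and shows that this position, on an aromatic carbon, tolerates this change very poorly. The two groups have the same counts of hydrogen-bond donors and acceptors and neither carries a net charge, so those counts do not separate them. Nothing at hand accounts for the size of this step. The compounds shown leave open whether the aromatic ring or the missing methyl group and stereocentre matters more. An unsubstituted pyrrolidin-1-yl or a 2-methyl-1H-pyrrol-1-yl group at this position would help separate these changes.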